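From 3-chlorophenyl to 4-chlorophenyl in the series

The source may report more compounds than this note shows. Statements on the series, on what has been measured and on what is new or still open speak of the compounds shown alone.

Of the compounds shown here, two have numbers so far in a functional assay on B16 cells (Mus musculus) for cytotoxicity, read by CCK-8 assay, with a stated time of 24 h; a higher number here means a weaker inhibitor, a lower number a stronger inhibitor. Compound 1 `COc1cccc(-c2nc(N)c(Oc3ccccc3OC)c(Cl)n2)c1` gives 23600 nM, and compound 2 `COc1ccccc1Oc1c(N)nc(-c2cccc(Cl)c2)nc1Cl` gives 17900 nM. These two values lie within the scatter of each other, so compound 2 holds no real rank in this pair. The next compound is compound 3 `COc1ccccc1Oc1c(N)nc(-c2ccc(Cl)cc2)nc1Cl`, and the change from compound 2 is 4-chlorophenyl in place of 3-chlorophenyl on an aromatic carbon. The aromatic carbon concerned lies between two ring nitrogen atoms, and the two groups have the same atoms, joined differently. Among the measured compounds shown here, the only measured step, a 1.3-fold lower number from compound 1 to compound 2 (0.12 log units; within the scatter), is chloro in place of methoxy, and it stays within the scatter. For the measured compounds named here, no measured pair compares 3-chlorophenyl with 4-chlorophenyl directly, so that step offers only weak guidance. Going by the values given here, with this small step as the sole evidence, no shift in either direction is expected beyond the scatter. The expected step, a 1.0-fold higher number from compound 2 to compound 3 (0.00 log units; within the scatter), is therefore estimated to be negligible. For compound 3 the estimated value in this assay is 18000 nM, with an expected range of 8000 nM to 40000 nM.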

Compound 3, half-maximal inhibitory concentration: 18800 nM
Compound 3: the middle estimate sits 1.0-fold (0.02 log units) below what was measured; the range from low to high includes it.
By their numbers in this assay, from the lowest: compounds 2, 3 and 1 (each within the scatter of the next).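

In this assay, the two chlorophenyl isomers now stand side by side on the aromatic carbon between two ring nitrogen atoms, and 4-chlorophenyl in place of 3-chlorophenyl gives no readable difference (a 1.1-fold higher number from compound 2 to compound 3 (0.02 log units; within the scatter)). The second new comparison, 4-chlorophenyl in place of 3-methoxyphenyl, also stays within the scatter (a 1.3-fold lower number from compound 1 to compound 3 (0.10 log units; within the scatter)), so 3-methoxyphenyl, 3-chlorophenyl and 4-chlorophenyl cannot be told apart at this place in this assay, and the earlier single step between compound 1 and compound 2 is no longer alone. No measurement at hand accounts for this flat reading.

The compounds shown leave open whether any replacement at this place can move the number beyond the scatter, for example a phenyl ring carrying a carboxylic acid or a dimethylamino group, or a saturated amine such as morpholine in place of the phenyl ring. They also leave open whether changes elsewhere on the shared core, such as swapping the amino group for a longer chain amine, would do so where these three aryl groups do not.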